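The source may report more compounds than this note shows. Statements on the series, on what has been measured and on what is new or still open speak of the compounds shown alone.

Compound 1 `CCOC(=O)N1CCN(/[N+]([O-])=N/Oc2cc(O/N=[N+](\[O-])N(C)C)c([N+](=O)[O-])cc2[N+](=O)[O-])CC1` gives 2000 nM in a functional assay on HL-60 cells (Homo sapiens) for antiproliferative activity, read by MTT assay, with a stated time of 72 h; a lower number here means a stronger inhibitor of growth, a higher number a weaker inhibitor of growth. Among the compounds with values here, compound 2 `CCN(CC)/[N+]([O-])=N/Oc1cc(O/N=[N+](\[O-])N(C)C)c([N+](=O)[O-])cc1[N+](=O)[O-]` gives 2300 nM in this assay; the only other number, that of compound 1, lies within the scatter of it. Compound 3 `CCOC(=O)N1CCN(/[N+]([O-])=N/Oc2cc(O/N=[N+](\[O-])N(CC)CC)c([N+](=O)[O-])cc2[N+](=O)[O-])CC1` differs from compound 2 by 4-(ethoxycarbonyl)piperazin-1-yl in place of dimethylamino on a double-bonded nitrogen. Within the data shown here, the one step that bears on this, a 1.2-fold higher number from compound 1 to compound 2 (0.06 log units; within the scatter), exchanged the same two kinds of amine at the other double-bonded nitrogen and stayed within the scatter, so no step beyond the scatter is expected in this assay for compound 3, the expected change being a 1.2-fold lower number from compound 2 to compound 3 (0.06 log units; within the scatter). Compound 3 is estimated at 2000 nM, with a range of 1000 nM to 4500 nM.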

Compound 3, concentration for total growth inhibition: 5000 nM
Estimate against measurement, compound 3: 2.5-fold (0.40 log units) below; the measured number lies above the stated range.
By their numbers in this assay, from the lowest: compounds 1 and 2 (each within the scatter of the next); then compound 3.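

In this assay, within the data shown here, the place on a double-bonded nitrogen that carries dimethylamino in compound 1 and compound 2 is the first to show a step beyond the scatter. Putting diethylamino there gives a 2.5-fold higher number from compound 1 to compound 3 (0.40 log units; beyond the scatter), and the exchange read against compound 2 gives a 2.2-fold higher number from compound 2 to compound 3 (0.34 log units; beyond the scatter), whereas a 1.2-fold higher number from compound 1 to compound 2 (0.06 log units; within the scatter) stayed within the scatter. Among these compounds, the two with dimethylamino lie together and compound 3, without it, stands higher. No measurement on hand accounts for this. Open, as far as these compounds go, is how pyrrolidin-1-yl, or a piperazine with a free ring amine, would read at this place.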